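The compounds below may be only part of what the source reports. "The series", "measured", "known", "first", "only" and "open" are said of these compounds alone.

Measured so far:
Compound 1 `CS(=O)(=O)N1CCC2(CC1)OOC1(CCCCCC1)OO2`: > 100 ug/mL
Compound 2 `CCCCS(=O)(=O)N1CCC2(CC1)OOC1(CCCC1)OO2`: > 100 ug/mL
Compound 3 `CCCCS(=O)(=O)N1CCC2(CC1)OOC1(CCCCC1)OO2`: > 100 ug/mL

In a functional assay on Huh-7 cells (Homo sapiens) for cytotoxicity, read by MTT assay, with a stated time of 72 h (a lower number here means that less compound is tolerated, a higher number that more compound is tolerated), compound 1 gives > 100 ug/mL, which is a limit of the assay and not a number. It shares this position with the other two compounds: the limit of > 100 ug/mL in this assay, at which 3 of the 3 values shown sit. Within the data shown here, no measured pair therefore gives a numerical step to build on.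

Compound 4 `O=S(=O)(Cc1ccccc1)N1CCC2(CC1)OOC1(CCCCCC1)OO2` has phenyl in place of hydrogen on a saturated chain carbon bound to a sulfonyl sulfur, so methyl becomes benzyl (phenyl in place of hydrogen on a saturated chain carbon bound to a sulfonyl sulfur). The expected step is a number no higher from compound 1 to compound 4 (the limit leaves the size open), estimated to be no larger than the usual scatter in this assay, with no direction expected. For compound 4 the estimated value is 100 ug/mL, with an expected range of 40 ug/mL to 200 ug/mL.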

Compound 4, half-maximal cytotoxic concentration: > 100 ug/mL
Compound 4: a limit, no number (the forecaster's own chance of this, stated with the estimate: 70%); the middle value sits exactly at the limit.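

No step can be read from compound 1 to compound 4, because both values are limits and not numbers: the limit of > 100 ug/mL in this assay, at which 4 of the 4 values shown sit.

The compounds shown leave open how much compound these cells tolerate, and whether any difference among the compounds changes that.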